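Dichlorophenyl to Difluorophenyl on the Ketone Side

This account rests on a few compounds, and the source may have more. Where it says the series, first, only, none or still open, it means among the compounds named here.

Three measured compounds share one core. Compound 1 `COc1ccc(-c2cc(/C=C/C(=O)c3ccc(N)cc3)[nH]n2)cc1` gives 45700 nM in a functional assay on SF-268 cells (Homo sapiens) for inhibition, read by sulforhodamine B assay, with a stated time of 48 h; a higher number here means that more compound is tolerated, a lower number that less compound is tolerated. Compound 3 `COc1ccc(C(=O)/C=C/c2cc(-c3cc(OC)c(OC)c(OC)c3)n[nH]2)cc1OC`, which carries a 3,4-dimethoxyphenyl on its carbonyl carbon, gives 8590 nM. Compound 2 `COc1cc(-c2cc(/C=C/C(=O)c3ccc(Cl)c(Cl)c3)[nH]n2)cc(OC)c1OC` reaches only the upper limit of this assay, > 100000 nM, so for it a limit rather than a number is known. It therefore stands at the limit of > 100000 nM in this assay, at which 1 of the 3 values shown sits. For the measured compounds named here, the one step measured within this set runs from compound 2 to compound 3: an at least 11-fold lower number from compound 2 to compound 3 (1.06 log units; beyond the scatter).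

Compound 4 `COc1cc(-c2cc(/C=C/C(=O)c3ccc(F)c(F)c3)[nH]n2)cc(OC)c1OC` is compound 2 with 3,4-difluorophenyl in place of 3,4-dichlorophenyl on a carbonyl carbon. The measured step exchanged the 3,4-dichlorophenyl for a 3,4-dimethoxyphenyl, not for another dihalogenated ring, so it bears only loosely on the present change. Going by the values given here, both the leaving and the entering group are six-membered carbon rings with two halogens in the same positions, and no measured pair here separates chlorine from fluorine. A step of modest size at most is expected, and the value of compound 4 may well sit at the limit again. From compound 2 the expected step is an at least 1.2-fold lower number from compound 2 to compound 4 (0.09 log units; that floor lies within the scatter). Compound 4 is estimated at 80000 nM, within 25000 nM to 250000 nM.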

Compound 4, concentration lethal to 50% of the cells: > 100000 nM
Compound 4 was reported as a limit (the forecaster's own chance of this, stated with the estimate: 50%); middle value at least 1.2-fold (0.09 log units) away from the limit.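

In this assay compound 4 gives > 100000 nM, which is a limit of the assay and not a number. The step between compound 2 and compound 4 cannot be read, because both sit at the same limit: the limit of > 100000 nM in this assay, at which 2 of the 4 values shown sit. What the new compound adds concerns the ring on the carbonyl carbon: until now the 3,4-dimethoxyphenyl had been compared with only one halogenated ring, and it now stands apart from a second, with an at least 11-fold higher number from compound 3 to compound 4 (1.06 log units; beyond the scatter), so among these three compounds only the one with the 3,4-dimethoxyphenyl gives a number rather than a limit.

As far as these compounds go, how far compound 2 and compound 4 lie past the limit stays unknown, so nothing can be said about whether chlorine and fluorine differ at this position. Also open, from the compounds shown here alone, is whether the number of compound 3 depends on the methoxy groups themselves or simply on the absence of halogens, and whether a 3,4-dihydroxyphenyl or a phenyl bearing a carboxylic acid on the same carbonyl carbon would give a number in this assay.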